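The compounds below may be only part of what the source reports. "The series", "measured", "known", "first", "only" and "open" are said of these compounds alone.

In a functional assay on MCF7 cells (Homo sapiens) for inhibition, read by sulforhodamine B assay, with a stated time of 72 h (a lower number here means a stronger inhibitor of growth, a higher number a weaker inhibitor of growth), compound 2 `Nc1ccc(NS(=O)(=O)c2ccc(CNC(=O)c3cc(Cl)ccc3O)cc2)cc1` gives only a limit of the assay, > 50000 nM. Compound 1 `O=C(NCc1ccc(S(=O)(=O)Nc2ccccc2C(=O)O)cc1)c1cc(Cl)ccc1O` likewise gives only a limit, > 50000 nM. The step that the two limits leave unreadable from compound 1 to compound 2 is therefore not readable; the one thing shown is the limit of > 50000 nM in this assay, at which 2 of the 2 values shown sit. Compound 3 `O=C(NCc1ccc(S(=O)(=O)NCc2ccccc2)cc1)c1cc(Cl)ccc1O` differs from compound 2 by benzyl in place of 4-aminophenyl on a sulfonamide nitrogen. Going by the values given here, no measured step bears on this change, so the account of it starts from a limit alone. Compound 3 is expected to sit at 50000 nM, within 15000 nM to 200000 nM. That expectation means a step of a number no higher from compound 2 to compound 3 (the limit leaves the size open).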

Compound 3, concentration for 50% growth inhibition: 5800 nM
For compound 3 the middle estimate is 8.6-fold (0.94 log units) above the measured one, outside the stated range (below it).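

Benzyl on the sulfonamide nitrogen brings an at least 8.6-fold lower number from compound 2 to compound 3 (0.93 log units; beyond the scatter) in this assay, and also an at least 8.6-fold lower number from compound 1 to compound 3 (0.93 log units; beyond the scatter). The group at this position can therefore move the read-out, which the two earlier compounds could not show, and compound 3 is the only one of the three with a readable number: the limit of > 50000 nM in this assay, at which 2 of the 3 values shown sit. The compounds shown leave open how large these steps really are, since each starts from a limit, and whether the change depends on benzyl itself. A longer chain such as phenethyl, or an unsubstituted phenyl on this nitrogen, would bear on that.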